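This account rests on a few compounds, and the source may have more. Where it says the series, first, only, none or still open, it means among the compounds named here.

Measured so far:
compound 1 `CC(C(=O)N1CCN(c2ccccc2F)CC1)N1C(=O)CCC1=O` with 100%
compound 2 `CC(C(=O)N1CCN(c2ccc(C(F)(F)F)cc2)CC1)N1C(=O)CCC1=O` with 25%
compound 3 `CC(C(=O)N1CCN(c2ccc(F)cc2)CC1)N1C(=O)CCC1=O` with 100%

In a functional assay on the whole organism (strain Swiss) with Mus musculus as the target, in the maximal electroshock model, with a stated time of 0.25 h, at a dose of 300 mg/kg by the intraperitoneal route (on this read-out lower numbers stand for a weaker effect and higher numbers for a stronger effect at the one dose given), compound 1 and compound 3 stand level, and no change at the digits printed from compound 1 to compound 3 (within the scatter). The two differ only in their cores: 2-fluorophenyl in place of 4-fluorophenyl on an amine nitrogen in a ring. Compound 2 shows what one replacement does on the core of compound 3: trifluoromethyl in place of fluoro on an aromatic carbon, and a number 75 percentage points lower from compound 3 to compound 2 (beyond the scatter).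

Compound 4 `CC(C(=O)N1CCN(c2ccccc2C(F)(F)F)CC1)N1C(=O)CCC1=O` is not yet measured. It carries the same kind of change, now on the core of compound 1: trifluoromethyl in place of fluoro on an aromatic carbon. The surroundings differ, since here the new group sits ortho to a large group, whereas in compound 2 it sits para to a large group, so the two changes are alike but not the same.

The expected step is a number 65 percentage points lower from compound 1 to compound 4 (beyond the scatter), resting on the fall seen as a number 75 percentage points lower from compound 3 to compound 2 (beyond the scatter). Compound 4 is therefore estimated at 35%.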

Compound 4, a percentage reported as activity, at one dose (the size of the read-out at that dose, not a potency): 100%
Beside the measured number, compound 4's estimate is 65 percentage points below it, outside the stated range (above it).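

Trifluoromethyl in place of fluoro on an aromatic carbon gives no change at the digits printed from compound 1 to compound 4 (within the scatter) in this assay. Set beside the same change on the other core, the outcome did not carry over: the same change on two cores in this assay, a number 75 percentage points lower (beyond the scatter) from compound 3 to compound 2 and no change at the digits printed (within the scatter) from compound 1 to compound 4, 75 percentage points apart, beyond the scatter of two such steps The fall seen on the core of compound 3 therefore cannot serve as a general rule for this change in the series, but these two pairs do not show why the cores part ways, and a read-out at one dose is not a measure of potency.

From the compounds shown here alone, what a methoxy group or a chlorine on that aromatic carbon would give on either core remains open. So does whether the two cores would still differ at a lower dose.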